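Compound 3: trifluoromethoxy for cyano

A few compounds are considered here, and "the series" means these few. Any claim that something is new, unique, unknown or untested is made for them only; others in the source may bear on it.

Compound 1 `N#Cc1ccc(NC(=O)c2cc(Cl)ccc2O)c(Cl)c1`: 500 nM
Compound 2 `N#Cc1ccc(NC(=O)c2cc(Cl)ccc2O)cc1`: 700 nM

In a functional assay on HL-60 cells (Homo sapiens) for cytotoxicity, read by luminescence and CellTiter-Glo, with a stated time of 3 days (on this read-out lower numbers stand for stronger inhibition and higher numbers for weaker inhibition), compound 1 has only compound 2 for comparison, and the two values lie within the scatter of each other, so no order is drawn between them. Compound 3 `O=C(Nc1ccc(OC(F)(F)F)cc1Cl)c1cc(Cl)ccc1O` differs from compound 1 by trifluoromethoxy in place of cyano on an aromatic carbon. Among the measured compounds shown here, the only measured step, a 1.4-fold higher number from compound 1 to compound 2 (0.15 log units; within the scatter), lies within the scatter. It is hydrogen in place of chloro, a different change, so it bears on this one only weakly. For the measured compounds named here, no measured step covers the loss of cyano, so the range is kept wide and no firm direction is claimed. The expected change is a 1.3-fold lower number from compound 1 to compound 3 (0.10 log units; within the scatter), which is estimated to stay within the scatter. Compound 3 is estimated at 400 nM, with an expected range of 120 nM to 1400 nM.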

Compound 3, half-maximal inhibitory concentration: 650 nM
Compound 3: middle estimate off by 1.6-fold (0.21 log units), on the low side; the range from low to high includes it.
By their numbers in this assay, from the lowest: compounds 1, 3 and 2 (each within the scatter of the next).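

In this assay, a 1.3-fold higher number from compound 1 to compound 3 (0.11 log units; within the scatter) accompanies trifluoromethoxy in place of cyano on an aromatic carbon. This position, meta to a chloro group and para to a large group, therefore accepts a group of 5 heavy atoms in place of one of 2 heavy atoms without a step beyond the scatter, and the nitrile is not required for a value in this range, which the earlier hydrogen-for-chloro step could not show. No supporting data explain why the two values lie so close.

Going by these compounds, whether an amine, a carboxylic acid or a longer chain at this position would also stay within the scatter of compound 1 remains open. On these data alone, it is also open whether hydrogen in place of chloro would give a similarly small step with trifluoromethoxy present.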